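This account rests on a few compounds, and the source may have more. Where it says the series, first, only, none or still open, it means among the compounds named here.

Series around the shared core of compound 1 `NC(=O)c1cc(Cl)c2c(Cl)c(C#CC3CCOCC3)n([C@H]3CCCNC3)c2n1`, varied at the group on the triple-bonded carbon. In a functional assay on KG-1 cells (Homo sapiens) for antiproliferative activity (on this read-out lower numbers stand for an effect already at smaller amounts and higher numbers for an effect only at larger amounts of compound), compound 1 gives 69 nM, the lowest of the two single numbers in hand. Compound 3 `CC1(CC#Cc2c(Cl)c3c(Cl)cc(C(N)=O)nc3n2[C@H]2CCCNC2)COC1` gives 289 nM in this assay; the step of a 4.2-fold higher number from compound 1 to compound 3 (0.62 log units; beyond the scatter) is a modest loss. Compound 2 `NC(=O)c1cc(Cl)c2c(Cl)c(C#CC3CNCCO3)n([C@H]3CCCNC3)c2n1` has two entries in this assay, 365 nM; 197 nM (2 entries), both above the number for compound 1; the repeat entries of compound 2, (the several entries of compound 2 in this assay, 365 nM; 197 nM (2 entries)), show the spread between runs of this kind. Compound 4 `CC(C)(O)C#Cc1c(Cl)c2c(Cl)cc(C(N)=O)nc2n1[C@H]1CCCNC1` has yet to be measured in this assay. It differs from compound 1 at one place: 1-hydroxy-1-methylethyl in place of oxan-4-yl on a triple-bonded carbon. Among the compounds with values here, the one measured step that bears on this, a 4.2-fold higher number from compound 1 to compound 3 (0.62 log units; beyond the scatter), also removed oxan-4-yl from the triple-bonded carbon and raised the number modestly; the pair of compound 1 and compound 2 points the same way. A rise of similar size is therefore expected for compound 4, a 2.9-fold higher number from compound 1 to compound 4 (0.46 log units; beyond the scatter). Compound 4 is estimated at 200 nM, with a range from 80 nM to 500 nM.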

Compound 4, half-maximal effective concentration: 302 nM
Beside the measured number, compound 4's estimate is 1.5-fold (0.18 log units) below it, and the stated range covers the measured number.
By their numbers in this assay, from the lowest: compound 1; then compounds 3 and 4 (each within the scatter of the next).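

The change to 1-hydroxy-1-methylethyl, which has no ring and brings 1 hydrogen-bond donor, gives a 4.4-fold higher number from compound 1 to compound 4 (0.64 log units; beyond the scatter) in this assay, so oxan-4-yl keeps the lowest single number even against this group of fewer heavy atoms. The replacement of (3-methyloxetan-3-yl)methyl by 1-hydroxy-1-methylethyl gives a 1.0-fold higher number from compound 3 to compound 4 (0.02 log units; within the scatter), so these two replacements of oxan-4-yl cannot be told apart in this read-out. That gap is small beside the spread between repeat runs: the several entries of compound 2 in this assay, 365 nM; 197 nM (2 entries).

Within the data shown here, whether the rise follows from losing the six-membered ring, from the added hydroxyl or from the lower heavy-atom count stays open, as no pair here changes one of these alone. Also open, as far as these compounds go, is how a carboxylic acid or a longer chain ending in a hydroxyl would read on the triple-bonded carbon.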